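A Carboxyethyl Side Chain on a Shared Core

The compounds below may be only part of what the source reports. "The series", "measured", "known", "first", "only" and "open" are said of these compounds alone.

Measured compounds and their values:
compound 1, `NCCNC(=O)Cn1nc(N)c2c(C(F)(F)F)cc(-c3ccccc3)nc21`: 42900 nM
compound 2, `Nc1nn(CC(=O)NCCO)c2nc(-c3ccccc3)cc(C(F)(F)F)c12`: 78200 nM
compound 3, `Nc1nn(CC(=O)N2CCCC2)c2nc(-c3ccccc3)cc(C(F)(F)F)c12`: 15900 nM

All three compounds share one core and differ only in the group attached to the carbonyl carbon of the side chain. In a functional assay on MCF7 cells (Homo sapiens) for cytotoxicity, read by MTT assay, with a stated time of 24 h (on this read-out lower numbers stand for stronger inhibition and higher numbers for weaker inhibition), compound 2 gives the highest number of the three. Its step to compound 1 is small, a 1.8-fold higher number from compound 1 to compound 2 (0.26 log units; within the scatter), so the two cannot be ranked against each other. Compound 3, with pyrrolidin-1-yl in place of (2-hydroxyethyl)amino on the carbonyl carbon, lies further away, a 4.9-fold lower number from compound 2 to compound 3 (0.69 log units; beyond the scatter), a modest but real difference.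

Compound 4, `CC(NC(=O)Cn1nc(N)c2c(C(F)(F)F)cc(-c3ccccc3)nc21)C(=O)O`, keeps the amide-type nitrogen of compound 2 and changes what hangs from it: 1-carboxyethyl in place of 2-hydroxyethyl on an amide-type nitrogen.

Among the compounds with values here, two measured steps bear on this change. The step of a 1.8-fold higher number from compound 1 to compound 2 (0.26 log units; within the scatter) shows that swapping one small polar group for another at the end of the chain barely moves the number. The step of a 4.9-fold lower number from compound 2 to compound 3 (0.69 log units; beyond the scatter) shows that replacing the whole chain with a ring shifts it modestly. Within the data shown here, no measured step introduces a carboxylic acid. The nearest comparison, compound 1 to compound 2, suggests a step within the scatter, so compound 4 is expected to stay close to compound 2, a 1.0-fold higher number from compound 2 to compound 4 (0.01 log units; within the scatter). Compound 4 is therefore estimated at 80000 nM, with a range from 30000 nM to 200000 nM.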

Compound 4, half-maximal inhibitory concentration: 19900 nM
Compound 4: middle estimate off by 4.0-fold (0.60 log units), on the high side; the whole stated range lies above it.
By their numbers in this assay, from the lowest: compounds 3 and 4 (each within the scatter of the next); then compounds 1 and 2 (each within the scatter of the next).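

In this assay, on these data alone, the group on the amide-type nitrogen turns out to matter even when the chain stays open: 1-carboxyethyl in place of 2-hydroxyethyl gives a 3.9-fold lower number from compound 2 to compound 4 (0.59 log units; beyond the scatter) and so moves the number beyond the scatter, which the swap of amino for hydroxy at the chain end did not do. Within the data shown here, the 2-aminoethyl chain gives the same picture, with a 2.2-fold lower number from compound 1 to compound 4 (0.33 log units; beyond the scatter) as its step, while a 1.3-fold higher number from compound 3 to compound 4 (0.10 log units; within the scatter) leaves those two unranked, so an open chain here can match the level previously seen only with the pyrrolidin-1-yl ring. Nothing in the available data explains why this change lowers the number.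

As far as these compounds go, what remains open is which part of 1-carboxyethyl goes with this step, the carboxylic acid or its methyl branch. A carboxymethyl group on the same nitrogen, or a methyl ester in place of the acid, would help separate the two.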